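Methylsulfonyl in Place of Methylsulfanyl on Compound 3

This account rests on a few compounds, and the source may have more. Where it says the series, first, only, none or still open, it means among the compounds named here.

Compound 1, `Cc1cn2cccc(OCc3ccccc3)c2n1`: 62%
Compound 2, `CC(=O)c1c(C)nc2c(OCc3ccccc3)cccn12`: 57%
Compound 3, `CSCc1c(C)nc2c(OCc3ccccc3)cccn12`: 29%

In a functional assay on the whole organism with Rattus norvegicus as the target, with a stated time of 4 h, at a dose of 40 mg/kg by the intraperitoneal route (on this read-out higher numbers stand for more inhibition at the one dose given (going by the name of the read-out) and lower numbers for less inhibition), compound 3 stands lowest of the three numbers. The steps into it are a number 33 percentage points lower from compound 1 to compound 3 (beyond the scatter) and a number 28 percentage points lower from compound 2 to compound 3 (beyond the scatter), both beyond the scatter, whereas a number 5 percentage points lower from compound 1 to compound 2 (within the scatter). Compound 4, `Cc1nc2c(OCc3ccccc3)cccn2c1CS(C)(=O)=O`, differs from compound 3 in one place: methylsulfonyl in place of methylsulfanyl on a saturated chain carbon bound to an aromatic carbon. Going by the values given here, no measured step exchanges methylsulfanyl for methylsulfonyl, so the only guide is the pair of steps into compound 3, and those concern the whole (methylsulfanyl)methyl group against hydrogen or acetyl, not the change within it. The step of a number 7 percentage points higher from compound 3 to compound 4 (within the scatter) is therefore expected to stay within the scatter, with a wide range on either side. For compound 4 the estimate in this assay is 36%, from 12% to 62%.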

Compound 4, a percentage reported as inhibition, in the whole organism at one dose (the size of the read-out at that dose, not a potency): 61%
The estimate for compound 4 lay 25 percentage points below the measured number; measured number inside the range.
By their numbers in this assay, from the lowest: compound 3; then compounds 2, 4 and 1 (each within the scatter of the next).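

In this assay, going by these compounds alone, the change within the side chain proves decisive, with methylsulfonyl in place of methylsulfanyl giving a number 32 percentage points higher from compound 3 to compound 4 (beyond the scatter) and removing the loss seen only with compound 3. The (methylsulfonyl)methyl group matches acetyl, with a number 4 percentage points higher from compound 2 to compound 4 (within the scatter) and matches hydrogen, with a number 1 percentage points lower from compound 1 to compound 4 (within the scatter) so of the groups shown on this aromatic carbon only the (methylsulfanyl)methyl group of compound 3 goes against this level. Nothing available accounts for the gap between the two sulfur groups.

Going by these compounds, whether methylsulfinyl on the same saturated chain carbon would stand with compound 3 or with compound 4 remains open. So does the standing of an amine or a carboxylic acid there.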